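Substituent change on the aromatic carbon of compound 2

This account rests on a few compounds, and the source may have more. Where it says the series, first, only, none or still open, it means among the compounds named here.

Compound 2 `Cc1c(CO)c(CO)c2n1[C@@H](c1ccccc1)SC2` holds the lowest number of the three measured: in a functional assay on MCF7 cells (Homo sapiens) for cytotoxicity, read by MTT assay, with a stated time of 96 h (on this read-out lower numbers stand for stronger inhibition and higher numbers for weaker inhibition), compound 2 gives 600 nM. Compound 1 `Cc1cc(CO)c2n1[C@@H](c1ccccc1)SC2` gives 19900 nM and compound 3 `Cc1c(CO)c(CO)c2n1CSC2` gives 21500 nM. The step of a 33-fold lower number from compound 1 to compound 2 (1.52 log units; beyond the scatter) and the step of a 36-fold higher number from compound 2 to compound 3 (1.55 log units; beyond the scatter) are both large, yet neither touches the methyl group. Compound 4 `OCc1c(CO)c(-c2ccc(F)cc2)n2c1CS[C@@H]2c1ccccc1` differs from compound 2 by 4-fluorophenyl in place of methyl on an aromatic carbon. Among the measured compounds shown here, no measured step shows the same change, so the direction is open; the only aromatic-ring removal on record, the step from compound 2 to compound 3, suggests aromatic groups are tolerated here. Compound 4 is expected near compound 2, with a step of a 1.3-fold higher number from compound 2 to compound 4 (0.12 log units; within the scatter), estimated at 800 nM within 150 nM to 5000 nM.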

Compound 4, half-maximal inhibitory concentration: 26400 nM
Estimate against measurement, compound 4: 33-fold (1.52 log units) below, outside the stated range (above it).
By their numbers in this assay, from the lowest: compound 2; then compounds 1, 3 and 4 (each within the scatter of the next).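

Among the compounds shown here, the methyl-bearing aromatic carbon, next to the ring nitrogen, proves as sensitive as the sites of the earlier steps: 4-fluorophenyl in place of methyl gives a 44-fold higher number from compound 2 to compound 4 (1.64 log units; beyond the scatter) in this assay. An aromatic ring entering here therefore does not keep the number of compound 2. No evidence on hand bears on the reason for this step.

The compounds shown leave open whether the fluorine or the aromatic ring carries this step. Also open, as far as these compounds go, is whether ethyl, plain phenyl or an aminomethyl group on this carbon would stay near compound 2.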